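The source may hold more compounds than are shown below. What is called first, only, known or untested is meant among the compounds shown, and "the series" means these compounds.

Measured compounds and their values:
Compound 1 `Cc1c(Cc2ccccc2)c(=O)oc2cc(OCC(O)CNc3nc4ccccc4[nH]3)ccc12`; in an ADME assay on A549 cells (Homo sapiens) for cytotoxicity, read by CellTiter-Glo (on this read-out lower numbers stand for higher toxicity in this test and higher numbers for lower toxicity in this test), compound 1 gives only a limit, > 100000 nM.
Compound 2 `Cc1c(Cc2ccc(-c3ccc(F)cc3)cc2)c(=O)oc2cc(OCC(O)CN3CCC(C(N)=O)CC3)ccc12`; in this assay compound 2 gives 19300 nM.
Compound 3 `Cc1c(Cc2ccccc2)c(=O)oc2cc(OCC(CN3CCC(C(N)=O)CC3)Oc3ccccc3F)ccc12`; in this assay compound 3 gives 79600 nM.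

Compound 3 stands at the higher of the two numbers that exist in this assay. Compound 2 is the nearest, with a lower number, and that gap lies beyond the usual scatter. Compound 1 sits at the limit of > 100000 nM in this assay, at which 1 of the 3 values shown sits, which is a limit and not a number.

Compound 4 `Cc1c(Cc2ccccc2)c(=O)oc2cc(OCC(CN3CCC(C(N)=O)CC3)Oc3ccc(-c4ncc(N)s4)cc3)ccc12` has not been measured yet. It differs from compound 3 in one place: 4-(5-amino-1,3-thiazol-2-yl)phenyl in place of 2-fluorophenyl on an oxygen on a saturated carbon. No pair of measured compounds differs in only one place, so no measured step in this assay speaks directly to this change, and no cause for the gap between compound 2 and compound 3 is known.

For compound 4 the expectation in this assay is a number somewhat lower than that of compound 3, with wide uncertainty. The expected step of a 1.6-fold lower number from compound 3 to compound 4 (0.20 log units; within the scatter) is estimated to be modest and may stay within the scatter. Compound 4 is expected to give 50000 nM, in a range from 15000 nM to 100000 nM.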

Compound 4, half-maximal cytotoxic concentration: > 100000 nM
Compound 4 was reported as a limit (the forecaster's own chance of this, stated with the estimate: 30%); middle value at least 2.0-fold (0.30 log units) from the limit.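

In this assay, among these compounds, putting 4-(5-amino-1,3-thiazol-2-yl)phenyl in place of 2-fluorophenyl on an oxygen on a saturated carbon is the only single-place change that can be read, and it gives an at least 1.2-fold higher number from compound 3 to compound 4 (0.09 log units; that floor lies within the scatter). This place therefore takes the larger group, with its added five-membered aromatic ring and hydrogen-bond donor, without any lower number appearing in this test, although the floor of the step does not show a real rise. The read-out for compound 4 is a limit and not a number: the limit of > 100000 nM in this assay, at which 2 of the 4 values shown sit.

As far as these compounds go, the true size of the step from the 2-fluorophenyl compound stays open, as does the question of whether the outcome follows the amine, the thiazole ring or the added phenyl-linked bulk as a whole. An unsubstituted phenyl at this place, or a carboxylic acid in place of the amine on the thiazole ring, would separate these parts, and a value below the limit in such a compound would give the series a measurable step at this position.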